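The source may hold more compounds than are shown below. What is called first, only, known or untested is meant among the compounds shown, and "the series" means these compounds.

Working notes on the hydrazide series in an assay on isolated protein for inhibition of histone deacetylase 8 (Homo sapiens), read by fluorescence, with a stated time of 5 min; a lower number here means a stronger inhibitor, a higher number a weaker inhibitor.

Compound 1 `CCCNNC(=O)c1cnc(N2CCN(Cc3c[nH]c4ccccc34)CC2)nc1` gives 8.2 nM. Compound 2 `CCCCCCNNC(=O)c1ccc(-c2ccc(CNC(C)=O)cc2)cc1` gives 36 nM. Compound 3 `CCCNNC(=O)c1cnc(NCc2ccccc2)nc1` gives 1000 nM, the highest number of the three; the nearest number belongs to compound 2 and the furthest to compound 1, and both gaps lie well beyond the scatter. Among the compounds with values here, compound 1 and compound 3 share the same core and the same chain on the hydrazide but differ in the group on the core, which is the widest gap of the set; no single step between them is counted here.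

Compound 4 `CCCCCCNNC(=O)c1cnc(NCc2ccccc2)nc1` has not yet been measured. Compared with compound 3 the change is propyl in place of hydrogen on a saturated chain carbon, three bonds along the chain from an amine nitrogen, giving the same hexyl hydrazide that compound 2 carries on a different core. Within the data shown here, no counted step between measured compounds covers this change, so the expectation rests on what the three numbers show: compound 2, with the longer chain, gives 36 nM, whereas the shorter chain on the core of compound 3 gives 1000 nM. From compound 3 to compound 4 a step of about a 3.3-fold lower number from compound 3 to compound 4 (0.52 log units; beyond the scatter) towards a lower number is expected, though the different cores of compound 2 and compound 3 leave this uncertain. Compound 4 is estimated at 300 nM, within 60 nM to 1500 nM.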

Compound 4, half-maximal inhibitory concentration: 16 nM
The estimate for compound 4 lay 19-fold (1.27 log units) above the measured number; measured number below the stated range.
By their numbers in this assay, from the lowest: compounds 1 and 4 (each within the scatter of the next); then compound 2; then compound 3.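

In this assay the chain on the hydrazide emerges as a strong lever on this core: with the group on the core held constant, propyl in place of hydrogen on a saturated chain carbon, three bonds along the chain from an amine nitrogen, gives a 63-fold lower number from compound 3 to compound 4 (1.80 log units; beyond the scatter) and turns the propyl hydrazide into the hexyl hydrazide. Within the data shown here, the earlier compounds could not isolate this contribution, since their chain lengths were seen only alongside a change of core or of the group on it, whereas this is the first change confined to one place. No measurement shown accounts for the size of the step, so it stands as an observation without a cause.

The compounds shown give only the two ends of this chain, so it remains open whether butyl or pentyl already captures part of the step and whether a longer chain, or a chain ending in an amine or a carboxylic acid, keeps it. Also open, going by these compounds, is whether the same extension carries over to compound 1, whose group on the core differs from that of compound 3 and compound 4.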